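The source may report more compounds than this note shows. Statements on the series, on what has been measured and on what is new or still open speak of the compounds shown alone.

Compound 1 `[N-]=[N+]=NCC(O)Cn1c(=O)n(C2OC(CO)[C@@H](O)[C@H]2O)c2nc(N)nc(O)c21` is one of three compounds tested in a functional assay (B cells) with Mus musculus as the target; on this read-out higher numbers stand for an effect only at larger amounts of compound and lower numbers for an effect already at smaller amounts. Compound 1 gives 39 uM there, the second highest of the three numbers. Compound 2 `C=CCn1c(=O)n(C2CCC(CO)C2)c2nc(N)nc(O)c21` gives 226 uM in this assay, a higher number, so its effect appears only at a larger amount. Compound 3 `C=CCn1c(=O)n(C2CN(CCCC)CC(CO)O2)c2nc(N)nc(O)c21` gives 5 uM in this assay, the lowest of the three, so its effect appears already at the smallest amount; both of these differences from compound 1 lie beyond the usual scatter. Compound 4 `CN(C)CCCn1c(=O)n(C2OC(CO)[C@@H](O)[C@H]2O)c2nc(N)nc(O)c21` has not yet been measured. It shares the core and the sugar-like ring of compound 1 and differs only in the chain on the ring nitrogen: 2-(dimethylamino)ethyl in place of 2-azido-1-hydroxyethyl on a saturated chain carbon bound to an aromatic nitrogen. For the measured compounds named here, no pair among the measured compounds shows this change on its own, so there is no directly comparable step. Going by the values given here, since the one compound with a nitrogen-bearing side chain, compound 3, gives 5 uM, a move toward a somewhat lower number is expected for compound 4, with a 2.0-fold lower number from compound 1 to compound 4 (0.29 log units; within the scatter) as the expected step. In this assay compound 4 is thus estimated at 20 uM, with a likely range from 5 uM to 80 uM.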

Compound 4, concentration for half-maximal effect: 194 uM
Compound 4: middle estimate off by 9.7-fold (0.99 log units), on the low side; measured number above the stated range.
By their numbers in this assay, from the lowest: compound 3; then compound 1; then compounds 4 and 2 (each within the scatter of the next).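

Replacing 2-azido-1-hydroxyethyl with 2-(dimethylamino)ethyl, on a saturated chain carbon bound to an aromatic nitrogen, gives a 5.0-fold higher number from compound 1 to compound 4 (0.70 log units; beyond the scatter) in this assay. For the compounds shown here, since the shared core and the sugar-like ring stay the same, this is the first direct sign that the chain at this place affects the read-out, and that this dimethylamino-bearing chain moves the number upward rather than downward. Nothing measured here explains the shift.

Going by these compounds, the azido group and the hydroxyl leave together in this single step, so their separate contributions remain open. A 3-azidopropyl or 3-hydroxypropyl chain on the same core could separate the two, while a longer chain ending in dimethylamino could test whether chain length matters.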